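Piperazine for piperidine on the two-carbon chain

The source may report more compounds than this note shows. Statements on the series, on what has been measured and on what is new or still open speak of the compounds shown alone.

Among the compounds with values here, compound 2 `c1ccc2c(c1)CN[C@@H](CN(CCC1CCNCC1)[C@H]1CCCc3cccnc31)C2` gives 150 nM in a functional assay on CCRF-CEM cells for antagonist activity at C-X-C chemokine receptor type 4 (Homo sapiens), read by calcium flux, with stated times of 25 min and 90 s (a lower number here means a stronger inhibitor, a higher number a weaker inhibitor), the lowest number of the three measured so far. Compound 1 `c1ccc2c(c1)CN[C@H](CN(CCCN1CCNCC1)[C@H]1CCCc3cccnc31)C2` gives 1150 nM and compound 3 `CN1CCN(CCCN(C[C@H]2Cc3ccccc3CN2C)[C@H]2CCCc3cccnc32)CC1` gives 536 nM; both stand beyond the scatter from compound 2, so compound 2 is the strongest inhibitor among the measured set. Within the data shown here, no pair in the set differs in only one place, so no single-change step is available as a guide.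

Compound 4 `c1ccc2c(c1)CN[C@@H](CN(CCN1CCNCC1)[C@H]1CCCc3cccnc31)C2` has not been measured. It differs from compound 2 by piperazin-1-yl in place of piperidin-4-yl on a saturated chain carbon, two bonds along the chain from an amine nitrogen. Among the measured compounds shown here, the only measured compound carrying a piperazin-1-yl group, compound 1, gives a markedly higher number than compound 2, but it differs from compound 2 in more than one place, so its value shows only that a piperazine-bearing analogue can sit well above compound 2.

A modest loss is expected: compound 4 is estimated at 400 nM in this assay, within 150 nM to 1200 nM, the step of a 2.7-fold higher number from compound 2 to compound 4 (0.43 log units; beyond the scatter) being expected to fall at or just beyond the scatter.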

Compound 4, half-maximal inhibitory concentration: 553 nM
Compound 4: middle estimate off by 1.4-fold (0.14 log units), on the low side; the measured number falls inside the stated range.
By their numbers in this assay, from the lowest: compound 2; then compounds 3 and 4 (each within the scatter of the next); then compound 1.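

In this assay, the change from piperidin-4-yl to piperazin-1-yl, on a saturated chain carbon, two bonds along the chain from an amine nitrogen, now has a size of its own: a 3.7-fold higher number from compound 2 to compound 4 (0.57 log units; beyond the scatter), with a ring nitrogen in place of a ring carbon as the only difference. Compound 1 could not show this, as it differs from compound 2 in more than one place, whereas this pair isolates the change. Nothing in hand explains the size of the step.

From the compounds shown here alone, it remains open whether a morpholin-4-yl group or an open-chain primary amine at this position would stay nearer compound 2 or move as compound 4 does. Also open, going by these compounds, is whether the same step would hold on a longer chain, with the rest of the molecule unchanged.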